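Removing One Methoxy Group from Compound 2

A few compounds are considered here, and "the series" means these few. Any claim that something is new, unique, unknown or untested is made for them only; others in the source may bear on it.

Measured compounds:
compound 1, `COc1ccc(-c2cc(/C=C/C(=O)c3ccc(N)cc3)[nH]n2)cc1`, 3620 nM
compound 2, `COc1cc(-c2cc(/C=C/C(=O)c3ccc(N)cc3)[nH]n2)cc(OC)c1OC`, 6760 nM

In a functional assay on HCT-15 cells (Homo sapiens) for inhibition, read by sulforhodamine B assay, with a stated time of 48 h (a higher number here means a weaker inhibitor of growth, a lower number a stronger inhibitor of growth), compound 1 gives 3620 nM, and in the same assay compound 2 gives 6760 nM. On these two numbers compound 2 stands alongside compound 1: the gap between them lies within the usual scatter, so nothing separates the two compounds here.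

Compound 3, `COc1ccc(-c2cc(/C=C/C(=O)c3ccc(N)cc3)[nH]n2)cc1OC`, has not yet been measured in this assay. It differs from compound 2 in one place: hydrogen in place of methoxy on an aromatic carbon. Since compound 1 and compound 2 are not separated beyond the scatter, no step beyond the scatter is expected for compound 3 either, and the expected step of a 1.4-fold lower number from compound 2 to compound 3 (0.15 log units; within the scatter) is small. Compound 3 is therefore estimated at 4800 nM, with a range from 2000 nM to 11000 nM.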

Compound 3, concentration for total growth inhibition: 5370 nM
For compound 3 the middle estimate is 1.1-fold (0.05 log units) below the measured one; the measured number falls inside the stated range.
By their numbers in this assay, from the lowest: compounds 1, 3 and 2 (each within the scatter of the next).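

In this assay, the two single-place changes at this position give small steps: hydrogen in place of methoxy (a 1.3-fold lower number from compound 2 to compound 3 (0.10 log units; within the scatter)) and methoxy in place of hydrogen (a 1.5-fold higher number from compound 1 to compound 3 (0.17 log units; within the scatter)). Compound 1 and compound 2 differ in more than one place, whereas these steps isolate a single position, on an aromatic carbon ortho to a methoxy group and meta to a large group, and show that hydrogen and methoxy are not separated there in this assay. Nothing at hand explains why these numbers lie so close.

The compounds shown leave open whether a different group at this position, such as a hydroxyl group, an amine or a longer alkoxy chain, would produce a step beyond the scatter. They also leave open whether changes elsewhere on the core of compound 1 would do so.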